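Hydroxyalkyl amide series: from compound 3 to compound 4

A few compounds are considered here, and "the series" means these few. Any claim that something is new, unique, unknown or untested is made for them only; others in the source may bear on it.

In a functional assay on MCF7 cells (Homo sapiens) for antiproliferative activity, read by MTT assay, with a stated time of 24 h (on this read-out higher numbers stand for weaker inhibition and lower numbers for stronger inhibition), compound 1 (`CCn1c(C(=O)N[C@@H](C)CO)ccc1C(CC)(CC)c1ccc(OCS(=O)(=O)c2ccccc2)c(C)c1`) stands at 10800 nM and compound 2 (`CCn1c(C(=O)NCCO)ccc1C(CC)(CC)c1ccc(OCS(=O)(=O)c2ccccc2)c(C)c1`) at 15500 nM while compound 3 (`CCn1c(C(=O)NC(C)(C)CO)ccc1C(CC)(CC)c1ccc(OCS(=O)(=O)c2ccccc2)c(C)c1`) stands at 20700 nM and lies within the scatter of both. The next member, compound 4 (`CCn1c(C(=O)N[C@H](CO)C(C)C)ccc1C(CC)(CC)c1ccc(OCS(=O)(=O)c2ccccc2)c(C)c1`), differs from compound 3 on an amide-type nitrogen (1-(hydroxymethyl)-2-methylpropyl in place of 1-(hydroxymethyl)-1-methylethyl on an amide-type nitrogen), with 1-(hydroxymethyl)-2-methylpropyl in place of 1-(hydroxymethyl)-1-methylethyl.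

Among the compounds with values here, three measured steps bear on this change, as all of them fall on the same amide-type nitrogen: (a 1.4-fold higher number from compound 1 to compound 2 (0.16 log units; within the scatter)), (a 1.9-fold higher number from compound 1 to compound 3 (0.28 log units; within the scatter)) and (a 1.3-fold higher number from compound 2 to compound 3 (0.13 log units; within the scatter)). All three stay within the scatter and give no direction. None of these compounds carries the entering group, so the data offer only an extrapolation. No step beyond the scatter is therefore expected in this assay, and the estimated step (a 1.4-fold lower number from compound 3 to compound 4 (0.14 log units; within the scatter)) is no more than a central guess. The estimate for compound 4 is 15000 nM with an expected range from 7500 nM to 30000 nM on this read-out.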

Compound 4, half-maximal inhibitory concentration: 25500 nM
For compound 4 the middle estimate is 1.7-fold (0.23 log units) below the measured one, and the stated range covers the measured number.
By their numbers in this assay, from the lowest: compounds 1, 2, 3 and 4 (each within the scatter of the next, the first and the last beyond it).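

On an amide-type nitrogen, 1-(hydroxymethyl)-2-methylpropyl keeps the number in this assay close to those of two earlier side chains: a 1.2-fold higher number from compound 3 to compound 4 (0.09 log units; within the scatter) and a 1.6-fold higher number from compound 2 to compound 4 (0.22 log units; within the scatter) both stay within the scatter. Against 1-(hydroxymethyl)ethyl, however, a 2.4-fold higher number from compound 1 to compound 4 (0.37 log units; beyond the scatter) is the first step beyond the scatter at this place, though only a modest one, so the hydroxyalkyl amides now show a small but real spread between their two ends. Nothing measured here bears on the reason for that step.

Still open, going by these compounds, is whether a larger change at this nitrogen would move the number further in either direction. A carboxylic acid or an amine in place of the hydroxyl, or a longer chain such as 3-hydroxypropyl, would test this.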